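The compounds below may be only part of what the source reports. "The series", "measured", "known", "first", "only" and "open" are said of these compounds alone.

Working notes on the amide series. In an assay on Jurkat cells for activation of nuclear factor NF-kappa-B complex (Homo sapiens) (on this read-out higher numbers stand for weaker inhibition and lower numbers for stronger inhibition), compound 3 `O=C(Nc1cc(C(F)(F)F)cc(C(F)(F)F)c1)c1cnc(Cl)nc1C(F)(F)F` gives 50 nM, the lowest of the two numbers recorded. Compound 2 `CCCc1nc(Cl)ncc1C(=O)Nc1cc(C(F)(F)F)cc(C(F)(F)F)c1` gives 500 nM in this assay. Compound 1 `Cc1cc(C(=O)Nc2cc(C(F)(F)F)cc(C(F)(F)F)c2)nc(Cl)n1` gives > 10000 nM in this assay, which is a limit of the assay and not a number, as recorded at the limit of > 10000 nM in this assay, at which 1 of the 3 values shown sits.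

Going by the values given here, the one measured step that runs to compound 3 is a 10-fold lower number from compound 2 to compound 3 (1.00 log units; beyond the scatter). Compound 4 `Cc1nc(Cl)ncc1C(=O)Nc1cc(C(F)(F)F)cc(C(F)(F)F)c1`, not yet measured, differs from compound 3 by methyl in place of trifluoromethyl on an aromatic carbon. Among the compounds with values here, no measured pair shows methyl against trifluoromethyl on this core, so the only guide is that propyl in compound 2 and trifluoromethyl in compound 3 gave the numbers above. Taking the move away from trifluoromethyl as likely to cost something, but with no direct evidence on how much, compound 4 is estimated at 250 nM in this assay, in a range of 60 nM to 1000 nM. That estimate means a step of a 5.0-fold higher number from compound 3 to compound 4 (0.70 log units; beyond the scatter), expected rather than known.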

Compound 4, half-maximal inhibitory concentration: 50 nM
Beside the measured number, compound 4's estimate is 5.0-fold (0.70 log units) above it; measured number below the stated range.
By their numbers in this assay, from the lowest: compounds 3 and 4 (each within the scatter of the next); then compound 2. At a limit, above all of these: compound 1.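

In this assay, methyl in place of trifluoromethyl on this aromatic carbon gives no change at the digits printed from compound 3 to compound 4 (within the scatter), so the two groups cannot be told apart here, and the fluorine atoms are not required for the value seen with compound 3. The length of the chain does count at this carbon: going from propyl to methyl gives a 10-fold lower number from compound 2 to compound 4 (1.00 log units; beyond the scatter), which leaves compound 2 apart from the other two compounds that share this arrangement. The arrangement of the ring itself also counts, as 2-chloro-4-methylpyrimidin-5-yl in place of 2-chloro-6-methylpyrimidin-4-yl gives an at least 200-fold lower number from compound 1 to compound 4 (2.30 log units; beyond the scatter), a step read from a limit and not from a number: the limit of > 10000 nM in this assay, at which 1 of the 4 values shown sits.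

Open, from the compounds shown here alone, is whether ethyl or cyclopropyl at this carbon stays with compounds 3 and 4 or goes with compound 2, and what hydrogen or an amine would give there. Also open, going by these compounds, is whether the chloro group can give way to a methoxy group or an amine.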